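Carboxy in Place of Hydroxymethyl: Expected Effect on Potency

This account rests on a few compounds, and the source may have more. Where it says the series, first, only, none or still open, it means among the compounds named here.

Of the compounds shown here, three sharing one core have been measured. Compound 1 `NCc1cc(C(F)(F)F)ccc1CN(Cc1nc2ccccc2[nH]1)C1CCCc2cccnc21` carries a trifluoromethyl group and gives 51 nM in a functional assay on CEM-CCRF cells for antagonist activity at C-X-C chemokine receptor type 4 (Homo sapiens), read by calcium flux; a higher number here means a weaker inhibitor, a lower number a stronger inhibitor. Compound 2 `NCc1ccc(CN(Cc2nc3ccccc3[nH]2)C2CCCc3cccnc32)c(CN)c1` carries an aminomethyl group in that position and gives 10 nM in this assay. Compound 3 `NCc1cc(CO)ccc1CN(Cc1nc2ccccc2[nH]1)C1CCCc2cccnc21` carries a hydroxymethyl group there and gives 11 nM in this assay.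

Compound 3 thus stands close to compound 2 and well apart from compound 1: the step of a 4.6-fold lower number from compound 1 to compound 3 (0.67 log units; beyond the scatter) was modest, as was the step of a 5.1-fold lower number from compound 1 to compound 2 (0.71 log units; beyond the scatter), while the step of a 1.1-fold higher number from compound 2 to compound 3 (0.04 log units; within the scatter) fell within the scatter.

Compound 4 `NCc1cc(C(=O)O)ccc1CN(Cc1nc2ccccc2[nH]1)C1CCCc2cccnc21` has not yet been measured. It differs from compound 3 in one place: carboxy in place of hydroxymethyl on an aromatic carbon.

Among the compounds with values here, two measured steps bear on this change. The step of a 1.1-fold higher number from compound 2 to compound 3 (0.04 log units; within the scatter) shows that exchanging one group bearing a hydrogen-bond donor and acceptor for another at this position left the number essentially unchanged. The steps from compound 1 showed that only the move away from trifluoromethyl mattered. A carboxy group again brings a donor and an acceptor, so the expected step of a 1.4-fold higher number from compound 3 to compound 4 (0.13 log units; within the scatter) is small, most likely within the scatter. Compound 4 is therefore estimated at 15 nM, with a range from 5 nM to 45 nM.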

Compound 4, half-maximal inhibitory concentration: 126 nM
The estimate for compound 4 lay 8.4-fold (0.92 log units) below the measured number; the whole stated range lies below it.
By their numbers in this assay, from the lowest: compounds 2 and 3 (each within the scatter of the next); then compound 1; then compound 4.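

In this assay, the change to carboxy gave an 11-fold higher number from compound 3 to compound 4 (1.06 log units; beyond the scatter), and the comparison with aminomethyl gave a 13-fold higher number from compound 2 to compound 4 (1.10 log units; beyond the scatter), so this position does not treat all groups bearing a hydrogen-bond donor and acceptor alike. Carboxy also compares poorly with the group that had looked least favourable: the step is a 2.5-fold higher number from compound 1 to compound 4 (0.39 log units; beyond the scatter), which makes compound 4 the weakest of the four and shows that moving away from trifluoromethyl does not by itself preserve potency. Hydroxymethyl and carboxy have identical computed hydrogen-bond donor and acceptor counts, so those counts cannot separate them, and the structural differences that remain are the additional oxygen and the double bond outside aromatic rings.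

Nothing available here identifies which feature of carboxy accounts for the loss. A primary amide or a methyl ester at this position would help to show whether the carbonyl is enough for the loss or whether the carboxylic acid itself is needed, and the compounds shown do not settle that question.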